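Pyrazolylamino variation on a nitrile-bearing core

The compounds below may be only part of what the source reports. "The series", "measured", "known", "first", "only" and "open" are said of these compounds alone.

Compound 3 `C[C@@H]1CCCN1c1c(C#N)c2c(N)nc(Nc3cnn(C)c3)nc2n1C` is the reference point of this set. In an assay on isolated protein for inhibition of Leucine-rich repeat serine/threonine-protein kinase 2 variant G2019S (Homo sapiens), read by TR-FRET and LanthaScreen, with stated times of 50 min and 30 min, in the presence of a further agent that is not named here (on this read-out lower numbers stand for stronger inhibition and higher numbers for weaker inhibition), compound 3 gives 5 nM, the lowest of the three numbers in hand. Compound 2 `C[C@@H]1CCCN1c1c(C#N)c2c(N)ncnc2n1C` carries hydrogen where compound 3 carries the (1-methyl-1H-pyrazol-4-yl)amino group. In this assay compound 2 gives 11 nM; the step of a 2.2-fold lower number from compound 2 to compound 3 (0.34 log units; beyond the scatter) is modest but beyond the scatter. Compound 1 `Cc1c(Nc2nc(N)c3c(C#N)c(N4CCC[C@H]4C)n(C)c3n2)cnn1C` gives 43 nM in this assay, and the step of an 8.6-fold lower number from compound 1 to compound 3 (0.93 log units; beyond the scatter) is likewise modest. Between the two weaker compounds the step of a 3.9-fold lower number from compound 1 to compound 2 (0.59 log units; beyond the scatter) applies.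

Compound 4 `Cc1n[nH]cc1Nc1nc(N)c2c(C#N)c(N3CCC[C@H]3C)n(C)c2n1` has not yet been measured. It differs from compound 3 by 3-methyl-1H-pyrazol-4-yl in place of 1-methyl-1H-pyrazol-4-yl on a nitrogen on an aromatic ring. Among the compounds with values here, no measured step matches this change directly; the steps that bear on it are a 2.2-fold lower number from compound 2 to compound 3 (0.34 log units; beyond the scatter) and an 8.6-fold lower number from compound 1 to compound 3 (0.93 log units; beyond the scatter), both modest, which show that the pyrazolylamino substituent itself contributes only a little. Since the same atoms are retained, the step of a 1.6-fold higher number from compound 3 to compound 4 (0.20 log units; within the scatter) is expected to be small, most likely within the scatter, with a slight lean toward a higher number. Compound 4 is therefore estimated at 8 nM, with a range from 3 nM to 25 nM.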

Compound 4, half-maximal inhibitory concentration: 27 nM
Compound 4: the middle estimate sits 3.4-fold (0.53 log units) below what was measured; measured number outside the range, above it.
By their numbers in this assay, from the lowest: compound 3; then compound 2; then compounds 4 and 1 (each within the scatter of the next).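

In this assay, exchanging 1-methyl-1H-pyrazol-4-yl for 3-methyl-1H-pyrazol-4-yl keeps the same atoms but gives a 5.4-fold higher number from compound 3 to compound 4 (0.73 log units; beyond the scatter) and so shows that, on this nitrogen on an aromatic ring, the way the pyrazole is joined and methylated matters and not just its presence. Compared with hydrogen on the aromatic carbon, the new group gives a 2.5-fold higher number from compound 2 to compound 4 (0.39 log units; beyond the scatter), so compound 4 joins compound 1 on the higher side of compound 2, while compound 3 remains the only one of the pyrazolylamino compounds on the lower side. The step of a 1.6-fold lower number from compound 1 to compound 4 (0.20 log units; within the scatter) does not separate 3-methyl-1H-pyrazol-4-yl from 1,5-dimethyl-1H-pyrazol-4-yl, so among the compounds shown, both groups with a methyl on a ring carbon stand apart from the 1-methyl group of compound 3.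

Compound 4 gains a hydrogen-bond donor as well as moving the methyl, and the compounds shown do not separate these two changes; the unmethylated 1H-pyrazol-4-yl group or a 1-ethyl-1H-pyrazol-4-yl group would bear on that question. Nothing measured here beyond these inhibition numbers bears on why the two isomers differ.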